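Adding Chloro to Compound 3: Expected Tolerance

The source may hold more compounds than are shown below. What is called first, only, known or untested is meant among the compounds shown, and "the series" means these compounds.

Compound 1 `COc1ccc(-c2cc(NC(=O)c3ccccc3O)c[nH]c2=O)cc1`: > 100000 nM, a limit of the assay
Compound 2 `COc1ccc(-c2cc(NC(=O)c3cccc(OC)c3O)c[nH]c2=O)cc1`: 49200 nM
Compound 3 `CCOc1ccc(-c2cc(NC(=O)c3ccccc3O)c[nH]c2=O)cc1`: 41000 nM

In an ADME assay on HepG2 2.2.15 cells (Homo sapiens) for cytotoxicity, read by CCK-8 assay, with a stated time of 8 days (a higher number here means that more compound is tolerated, a lower number that less compound is tolerated), compound 2 and compound 3 sit within the scatter of each other, while compound 1 gave only a limit. Compound 4 `CCOc1ccc(-c2cc(NC(=O)c3ccc(Cl)cc3O)c[nH]c2=O)cc1` differs from compound 3 by one change chloro in place of hydrogen on an aromatic carbon, giving 4-chloro-2-hydroxyphenyl. For the measured compounds named here, two measured steps bear on it only loosely, each adding a different group: an at least 2.0-fold lower number from compound 1 to compound 2 (0.30 log units; that floor lies within the scatter) and an at least 2.4-fold lower number from compound 1 to compound 3 (0.38 log units; beyond the scatter). Neither adds chloro, but both point to a lower number, so a modest further fall is expected. The expected step is a 1.6-fold lower number from compound 3 to compound 4 (0.21 log units; within the scatter). For compound 4 the estimated value is 25000 nM, with an expected range of 8000 nM to 70000 nM.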

Compound 4, half-maximal cytotoxic concentration: 28600 nM
The estimate for compound 4 lay 1.1-fold (0.06 log units) below the measured number, within the range that was stated.
By their numbers in this assay, from the lowest: compounds 4, 3 and 2 (each within the scatter of the next). At a limit, above all of these: compound 1.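

In this assay, placing chloro meta to the hydroxy group and para to a large group gives a 1.4-fold lower number from compound 3 to compound 4 (0.16 log units; within the scatter), so this position accepts chloro with no shift in tolerance that can be told from repeat scatter. The step can be read in full, unlike the steps from compound 1, whose value is only a limit: the limit of > 100000 nM in this assay, at which 1 of the 4 values shown sits.

From the compounds shown here alone, whether an amine or a carboxylic acid at this position would move the number beyond the scatter stays open. So does whether chloro would behave alike on compound 1, with its methoxy group.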